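Swapping the benzyl group on sulfur in compound 3

The source may hold more compounds than are shown below. What is called first, only, known or untested is meant among the compounds shown, and "the series" means these compounds.

Among the compounds with values here, in a functional assay on DU-145 cells (Homo sapiens) for cytotoxicity, read by MTT assay (on this read-out higher numbers stand for weaker inhibition and lower numbers for stronger inhibition), compound 1 `COc1ccc2cc([C@H](C)c3nnc(SCc4ccc(F)cc4)n3-c3ccc(F)cc3)ccc2c1` gives 60200 nM, the only actual number so far. Compound 3 `COc1ccc(CSc2nnc([C@@H](C)c3ccc4cc(OC)ccc4c3)n2-c2ccc(F)cc2)cc1` gives <= 400000 nM, which is a limit. Compound 2 `COc1ccc2cc([C@H](C)c3nnc(SCc4c(Cl)cccc4Cl)n3-c3cccc(Cl)c3)ccc2c1`, which also carries 2,6-dichlorobenzyl, gives <= 400000 nM, likewise a limit. The series therefore rests largely on (the limit of <= 400000 nM in this assay, at which 2 of the 3 values shown sit). Within the data shown here, the one measured step that bears on the change, a step that the limit leaves unreadable from compound 1 to compound 3, also alters this benzyl group but offers no usable size.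

Compound 4 `COc1ccc2cc([C@H](C)c3nnc(SCc4c(Cl)cccc4Cl)n3-c3ccc(F)cc3)ccc2c1` differs from compound 3 by 2,6-dichlorophenyl in place of 4-methoxyphenyl on a saturated chain carbon bound to a sulfur. The expected step is a step that the limit leaves unreadable from compound 3 to compound 4, estimated loosely and with no firm direction. For compound 4 the estimate is 100000 nM, with an expected range of 30000 nM to 400000 nM.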

Compound 4, half-maximal inhibitory concentration: 12300 nM
Compound 4: the middle estimate sits 8.1-fold (0.91 log units) above what was measured, outside the stated range (below it).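

The saturated chain carbon bound to a sulfur now has a readable step in this assay: 2,6-dichlorophenyl in place of 4-fluorophenyl gives a 4.9-fold lower number from compound 1 to compound 4 (0.69 log units; beyond the scatter), so the number at this position does move with the aryl group. The steps to compound 4 from compound 2 and from compound 3 cannot be read: the limit of <= 400000 nM in this assay, at which 2 of the 4 values shown sit.

Going by these compounds, how much the group on the aromatic nitrogen contributes remains open. So does how a benzyl group carrying an amine or a carboxylic acid, or a longer chain on sulfur, would read in this assay.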